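From a 4-cyanophenyl to a 2-fluorophenyl on compound 1

The compounds below may be only part of what the source reports. "The series", "measured", "known", "first", "only" and "open" are said of these compounds alone.

In a functional assay on SMMC-7721 cells (Homo sapiens) for cytotoxicity, read by MTT assay, with a stated time of 24 h (on this read-out higher numbers stand for weaker inhibition and lower numbers for stronger inhibition), compound 1 (`N#Cc1ccc(/C=C2\CN(S(=O)(=O)c3ccc(F)cc3)C/C(=C\c3ccc(C#N)cc3)C2=O)cc1`) gives 20100 nM. This is the higher of the two numbers available, the other coming from compound 2 (`CC(=O)Nc1ccc(S(=O)(=O)N2C/C(=C\c3ccc(C#N)cc3)C(=O)/C(=C/c3ccc(C#N)cc3)C2)cc1`) at 7120 nM, so compound 1 is the weaker of the pair. The unmeasured compound 3 (`N#Cc1ccc(/C=C2\CN(S(=O)(=O)c3ccc(F)cc3)C/C(=C\c3ccccc3F)C2=O)cc1`) differs from compound 1 as follows: 2-fluorophenyl in place of 4-cyanophenyl on a double-bonded chain carbon bound to a double-bonded ring carbon. In words, 2-fluorophenyl stands in place of 4-cyanophenyl on a double-bonded chain carbon bound to a double-bonded ring carbon.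

Going by the values given here, the only measured step, a 2.8-fold lower number from compound 1 to compound 2 (0.45 log units; beyond the scatter), is modest and lies elsewhere, with acetamido in place of fluoro on an aromatic carbon. It therefore bears on the new change only as a guide to size. Among the compounds with values here, no measured compound carries the 2-fluorophenyl group, so the direction remains uncertain. Since compound 1 holds the higher number, a modest move downward is tentatively expected, though a result within the scatter would not be surprising. In this assay, the estimated step is a 2.2-fold lower number from compound 1 to compound 3 (0.35 log units; beyond the scatter). The estimate for compound 3 is 9000 nM, with an expected range from 2500 nM to 30000 nM.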

Compound 3, half-maximal inhibitory concentration: 10300 nM
For compound 3 the middle estimate is 1.1-fold (0.06 log units) below the measured one, and the stated range covers the measured number.
By their numbers in this assay, from the lowest: compounds 2, 3 and 1 (each within the scatter of the next, the first and the last beyond it).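

In this assay the exchange of 4-cyanophenyl for 2-fluorophenyl on a double-bonded chain carbon bound to a double-bonded ring carbon gives a 2.0-fold lower number from compound 1 to compound 3 (0.29 log units; within the scatter) and so stays within the usual scatter. Going by these compounds alone, this is the first reading at this position, as the earlier step concerned only acetamido in place of fluoro on an aromatic carbon, and it shows that one 4-cyanophenyl group, with its nitrile and its hydrogen-bond acceptor, can give way to 2-fluorophenyl without a change that these measurements can separate from repeat variation. No independent measurement is available that could explain this result.

Still open, as far as these compounds go, is whether the position would respond to a group further removed from these two, such as a methoxyphenyl group, a pyridine ring or a phenyl ring bearing a carboxylic acid or an amine. From the compounds shown here alone, it is equally open whether the acetamido group and 2-fluorophenyl would act independently if combined on the shared core, or what would follow if the remaining 4-cyanophenyl group were exchanged as well.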